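This account rests on a few compounds, and the source may have more. Where it says the series, first, only, none or still open, it means among the compounds named here.

- Compound 1 `C=C1C2=C(C(=O)N1OC)[C@H](OC(=O)CSc1nc3ccccc3o1)[C@@](C)(O)[C@H](CCCCC)O2`: 3900 nM
- Compound 2 `C=C1C2=C(C(=O)N1OC)[C@H](OC(=O)CSc1nc3ccccc3s1)[C@@](C)(O)[C@H](CCCCC)O2`: 6300 nM

Both values come from a functional assay on MCF7 cells (Homo sapiens) for cytotoxicity, read by MTT assay, with a stated time of 72 h; on this read-out lower numbers stand for stronger inhibition and higher numbers for weaker inhibition. Compound 2 stands within the scatter of compound 1. The next compound, compound 3 `C=C1C2=C(C(=O)N1OC)[C@H](OC(=O)CCCCCl)[C@@](C)(O)[C@H](CCCCC)O2`, carries 3-chloropropyl in place of (1,3-benzothiazol-2-yl)sulfanyl on a saturated chain carbon bound to a carbonyl carbon. Going by the values given here, only one measured step bears on this, a 1.6-fold higher number from compound 1 to compound 2 (0.21 log units; within the scatter). It exchanged 1,3-benzoxazol-2-yl for 1,3-benzothiazol-2-yl on a sulfur and stayed within the scatter, so it says little about losing that whole group. No clear direction is therefore expected in this assay, and the estimated change is only a 1.1-fold higher number from compound 2 to compound 3 (0.05 log units; within the scatter). For compound 3 the expected value is 7000 nM, with an estimated range of 2000 nM to 25000 nM.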

Compound 3, half-maximal inhibitory concentration: 5400 nM
Compound 3: middle estimate off by 1.3-fold (0.11 log units), on the high side; the measured number falls inside the stated range.
By their numbers in this assay, from the lowest: compounds 1, 3 and 2 (each within the scatter of the next).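

In this assay, 3-chloropropyl, which has no ring, in place of (1,3-benzothiazol-2-yl)sulfanyl gives a 1.2-fold lower number from compound 2 to compound 3 (0.07 log units; within the scatter), and in place of (1,3-benzoxazol-2-yl)sulfanyl it gives a 1.4-fold higher number from compound 1 to compound 3 (0.14 log units; within the scatter). The earlier step only exchanged one ring-bearing group for another, whereas these show that, on a saturated chain carbon bound to a carbonyl carbon, this read-out does not separate those ring-bearing groups from a much smaller chlorine-bearing chain. No measurement at hand explains this result.

On these data alone, whether an amine or a carboxylic acid at this place, or the same chain without its chlorine, would give a number beyond the scatter stays open.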